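Amino in place of hydroxy on compound 2

A few compounds are considered here, and "the series" means these few. Any claim that something is new, unique, unknown or untested is made for them only; others in the source may bear on it.

Going by the values given here, in a functional assay on SK-OV-3 cells (Homo sapiens) for cytotoxicity, read by trypan blue exclusion, with a stated time of 96 h (on this read-out higher numbers stand for weaker inhibition of growth and lower numbers for stronger inhibition of growth), compound 1 `COc1ccc(NS(=O)(=O)/C=C/c2c(OC)cc(OC)cc2OC)cc1` gives 100 nM and compound 2 `COc1cc(OC)c(/C=C/S(=O)(=O)Nc2ccc(OC)c(O)c2)c(OC)c1` gives 25 nM, the lower of the two numbers so far. Compound 3 `COc1cc(OC)c(/C=C/S(=O)(=O)Nc2ccc(OC)c(N)c2)c(OC)c1` departs from compound 2 at a single place: amino in place of hydroxy on an aromatic carbon. This is amino in place of hydroxy on an aromatic carbon, ortho to a methoxy group and meta to a large group. Among the compounds with values here, no measured compound carries amino, so the data give no direct reading of this exchange. Within the data shown here, only one measured step bears on it, at that same carbon: a 4.0-fold lower number from compound 1 to compound 2 (0.60 log units; beyond the scatter), with hydroxy in place of hydrogen. That modest step shows that the number can respond to a change at this carbon, but the exchange here is between two groups rather than the addition of one, so a smaller step is expected. The expected move is slightly toward a lower number, estimated as a 1.7-fold lower number from compound 2 to compound 3 (0.22 log units; within the scatter). Compound 3 is expected at 15 nM, with an estimated range of 4 nM to 60 nM.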

Compound 3, concentration for 50% growth inhibition: 8 nM
Compound 3: middle estimate off by 1.9-fold (0.27 log units), on the high side; the measured number falls inside the stated range.
By their numbers in this assay, from the lowest: compound 3; then compound 2; then compound 1.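

In this assay, the carbon ortho to a methoxy group and meta to a large group proves sensitive to which group it carries, and not only to whether it carries one: the exchange of hydroxy for amino, two groups with the same printed counts of heavy atoms, donors and acceptors, gives a 3.1-fold lower number from compound 2 to compound 3 (0.49 log units; beyond the scatter). Measured against hydrogen at this carbon, amino gives a 13-fold lower number from compound 1 to compound 3 (1.10 log units; beyond the scatter), a large step, where hydroxy gave only the modest 4.0-fold lower number from compound 1 to compound 2 (0.60 log units; beyond the scatter), so among these three compounds the number falls from hydrogen to hydroxy to amino. Nothing at hand accounts for the difference between amino and hydroxy at this carbon.

The compounds shown leave open whether the trend continues with other groups on this carbon, such as a methylamino group, an acetamido group or a fluorine atom. They also leave open whether amino keeps its advantage over hydroxy when the neighbouring methoxy group gives way to an ethoxy group, or when the shared core is changed elsewhere.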